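The compounds below may be only part of what the source reports. "The series", "measured", "known", "first", "only" and "open" are said of these compounds alone.

Measured so far: compound 1 `O=C(Nc1cc2cc[nH]c(=O)c2cc1Cl)[C@H]1CCCN1`, 130 nM; compound 2 `N[C@H]1CC[C@H](C(=O)Nc2cc3cc[nH]c(=O)c3cc2Cl)CC1`, 330 nM.

Going by the values given here, in an assay on isolated protein for inhibition of Rho-associated protein kinase 2 (Homo sapiens) (on this read-out lower numbers stand for stronger inhibition and higher numbers for weaker inhibition), compound 2 gives 330 nM, the higher of the two numbers recorded; the only neighbour is compound 1, which gives 130 nM. Among the compounds with values here, the one measured step, a 2.5-fold higher number from compound 1 to compound 2 (0.40 log units; beyond the scatter), is modest and lies beyond the scatter.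

Compound 3 `O=C(Nc1cc2cc[nH]c(=O)c2cc1Cl)[C@@H]1CCCN1` has not yet been measured. Relative to compound 2 the change is pyrrolidin-2-yl in place of 4-aminocyclohexyl on a carbonyl carbon. This is the reverse of the measured step from compound 1 to compound 2, with one difference: the pyrrolidin-2-yl group of compound 3 carries the opposite configuration at its single defined stereocentre to that of compound 1. As far as these compounds go, the reverse of a 2.5-fold higher number from compound 1 to compound 2 (0.40 log units; beyond the scatter) therefore bears directly on the step, but how much the change of configuration costs or gains is unknown from the two numbers in hand.

From the compounds shown here alone, on this basis a step in the lower direction, of roughly the size of the measured step, is expected for compound 3, a 1.7-fold lower number from compound 2 to compound 3 (0.22 log units; within the scatter), with a wide range because the configuration is untested. Compound 3 is estimated at 200 nM, between 50 nM and 1000 nM.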

Compound 3, half-maximal inhibitory concentration: 35 nM
Compound 3: the middle estimate sits 5.7-fold (0.76 log units) above what was measured; the whole stated range lies above it.
By their numbers in this assay, from the lowest: compound 3; then compound 1; then compound 2.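

In this assay, the configuration at the saturated ring carbon of the pyrrolidin-2-yl group proves to matter at this position: inversion alone gives a 3.7-fold lower number from compound 1 to compound 3 (0.57 log units; beyond the scatter), a step that compound 1 and compound 2 could not reveal. Going by these compounds alone, the size of the exchange of 4-aminocyclohexyl for pyrrolidin-2-yl on this carbonyl carbon therefore depends on the configuration of the entering group: the step in the lower direction with the stereocentre drawn S is a 9.4-fold lower number from compound 2 to compound 3 (0.97 log units; beyond the scatter), whereas the only earlier reading, made with the stereocentre drawn R, was a 2.5-fold higher number from compound 1 to compound 2 (0.40 log units; beyond the scatter). The gap between compound 1 and compound 3 can be assigned to the stereocentre and to nothing else in the structure, because no other feature separates the pair: the fact that compounds 1 and 3 differ only in the configuration as drawn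

As far as these compounds go, whether the preference for the S drawing carries over to a piperidin-2-yl group or an open-chain amine on the same carbonyl carbon remains open. Also open, from the compounds shown here alone, is whether it survives a change to the shared core, which is identical in all three compounds.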